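This account rests on a few compounds, and the source may have more. Where it says the series, first, only, none or still open, it means among the compounds named here.

Measured so far in an in vivo ADME assay on the whole organism for metabolic stability, with Homo sapiens as the target, read by LC-MS, at a dose of 160 mg/kg by the oral route; on this read-out lower numbers stand for a shorter-lived compound and higher numbers for a longer-lived compound:

compound 1, `CC(C)n1cc(OC(=O)C(C)(C)C)nc1N/C(=N\C(=O)C(C)(C)C)Nc1ccc(Cl)c(Cl)c1`: compound 1 gives > 1 h, which is a limit of the assay and not a number.
compound 2, `CC(C)N1CC(=O)N=C1N/C(=N\C(=O)C(C)(C)C)Nc1ccc(Cl)c(Cl)c1`: compound 2 gives > 1 h, again a limit of the assay.
compound 3, `CC(C)N1CC(=O)N=C1N/C(=N/c1ccc(Cl)c(Cl)c1)N1CCCC1`: compound 3 gives > 1 h, likewise a limit.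

Compound 2 therefore stands at the limit only; the numbers shown place it no higher or lower than the other two, since all three values sit at the limit of > 1 h in this assay, at which 3 of the 3 values shown sit. For the measured compounds named here, no step between measured compounds can be sized from this, and nothing separates the three.

Compound 4, `CC(C)N1CC(=O)N=C1N/C(=N\C(=O)OC(C)(C)C)Nc1ccc(Cl)c(Cl)c1`, differs from compound 2 in one place: tert-butoxy in place of tert-butyl on a carbonyl carbon. Going by the values given here, no measured step speaks to such a change in this assay, so the step expected from the structural change is none beyond the scatter: a step that the limit leaves unreadable from compound 2 to compound 4. Compound 4 is expected at 2 h, within a range from 1 h to 5 h, and the assay may well again report only its limit.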

Compound 4, half-life: 0.213 h
Estimate against measurement, compound 4: 9.4-fold (0.97 log units) above, outside the stated range (below it).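

In this assay, tert-butoxy in place of tert-butyl on a carbonyl carbon gives an at least 4.6-fold lower number from compound 2 to compound 4 (0.67 log units; beyond the scatter). For the compounds shown here, compound 4 gives 0.213 h, the first value that is a number and not a limit of the assay. Going by these compounds alone, this shows that a change at this one place can bring the read-out down to a measurable half-life, which the earlier compounds could not show, as their values offered nothing to compare: the limit of > 1 h in this assay, at which 3 of the 4 values shown sit.

As far as these compounds go, the full size of the step stays open, as compound 2 carries only a limit, and so does whether the added oxygen alone accounts for it. From the compounds shown here alone, how a methoxy or a dimethylamino group on this carbonyl carbon would read also remains open.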